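A few compounds are considered here, and "the series" means these few. Any claim that something is new, unique, unknown or untested is made for them only; others in the source may bear on it.

Measured compounds:
- Compound 1, `c1ccc(Oc2ccccc2C2=NC(c3ccccc3)CO2)cc1`: 5.61
- Compound 2, `Ic1ccccc1C1=NC(c2ccccc2)CO1`: 3.86
- Compound 3, `FC(F)(F)c1ccccc1C1=NC(c2ccccc2)CO1`: 3.71

In a physicochemical assay for lipophilicity (on this read-out higher numbers stand for higher lipophilicity and lower numbers for lower lipophilicity), compound 3 gives the lowest of the three numbers; compound 2 sits nearest to it, within the scatter, and compound 1 sits furthest, well beyond it.

The next compound, compound 4, `O=[N+]([O-])c1ccccc1C1=NC(c2ccccc2)CO1`, differs from compound 3 in one place: nitro in place of trifluoromethyl on an aromatic carbon.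

Of the measured steps, a number 1.75 log units lower from compound 1 to compound 2 (beyond the scatter) and a number 1.90 log units lower from compound 1 to compound 3 (beyond the scatter) concern the loss of phenoxy, and so do not bear directly on the present change. The step of a number 0.15 log units lower from compound 2 to compound 3 (within the scatter) shows that iodo and trifluoromethyl at this position give numbers that cannot be told apart, which also says nothing directly about nitro. Among the measured compounds shown here, no measured step therefore covers the move from trifluoromethyl to nitro, and the expectation below rests on the general position of compound 3 rather than on a matching step.

Compound 4 is expected to fall below compound 3, by a step of a number 1.11 log units lower from compound 3 to compound 4 (beyond the scatter), which would be beyond the scatter. The estimate for compound 4 is 2.6, in a range from 2.1 to 3.2.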

Compound 4, partition coefficient: 2.83
Estimate against measurement, compound 4: 0.23 log units below, within the range that was stated.
By their numbers in this assay, from the lowest: compound 4; then compounds 3 and 2 (each within the scatter of the next); then compound 1.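

In this assay, nitro is the first group shown at this aromatic carbon, ortho to a large group, that stands clearly apart from the others. Iodo and trifluoromethyl could not be told apart, yet putting nitro in place of trifluoromethyl gives a number 0.88 log units lower from compound 3 to compound 4 (beyond the scatter), and putting it in place of iodo gives a number 1.03 log units lower from compound 2 to compound 4 (beyond the scatter), so this position can separate groups that are not far apart in size: nitro enters with fewer heavy atoms than trifluoromethyl takes away, but only by a small count. Putting nitro in place of phenoxy gives a number 2.78 log units lower from compound 1 to compound 4 (beyond the scatter), the widest step at this position among the compounds shown, while no accompanying measurement explains why nitro gives the lowest number of the four.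

The compounds shown leave open where an amine, a carboxylic acid or a nitrile on the same carbon would fall relative to nitro and the other groups. They also leave open whether the step from trifluoromethyl to nitro would keep its size with the group placed elsewhere on this ring or on a different core.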